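A methyl on the cyclopropyl ring: what to expect

This account rests on a few compounds, and the source may have more. Where it says the series, first, only, none or still open, it means among the compounds named here.

Compound 1 `CS(=O)(=O)CCCn1c(Cn2c(=O)n(C3CC3)c3ccncc32)cc2cc(Cl)ccc21` was tested in an ADME assay on HeLa cells (Homo sapiens) for cytotoxicity, read by ATP content, with a stated time of 3 days; a higher number here means that more compound is tolerated, a lower number that less compound is tolerated. In this assay compound 1 gives > 50000 nM, which is a limit of the assay and not a number. Two neighbours have been measured. Compound 2 `N=C(CCCn1c(Cn2c(=O)n(C3CC3)c3ccncc32)cc2cc(Cl)ccc21)NO` carries a different group on the side chain. In this assay compound 2 gives > 50000 nM, again a limit. Compound 3 `CS(=O)(=O)CCCn1c(Cn2c(=O)n(C3CC3)c3ccncc32)cc2cc(C(F)(F)F)ccc21` carries a different substituent on the aromatic ring. In this assay compound 3 gives > 50000 nM, also a limit. The two steps, a step that the two limits leave unreadable from compound 1 to compound 2 and a step that the two limits leave unreadable from compound 1 to compound 3, therefore cannot be read in size or direction, since all three values sit at the same limit (the limit of > 50000 nM in this assay, at which 3 of the 3 values shown sit).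

Compound 4 `CC1(n2c(=O)n(Cc3cc4cc(Cl)ccc4n3CCCS(C)(=O)=O)c3cnccc32)CC1` differs from compound 1 by methyl in place of hydrogen on a saturated ring carbon of a three-membered non-aromatic ring of carbon only, so that cyclopropyl becomes 1-methylcyclopropyl. For the measured compounds named here, no measured step covers this change, and the two that exist give no readable size. The step expected is a step that the limit leaves unreadable from compound 1 to compound 4, most likely ending at a limit once more. Compound 4 is estimated at 80000 nM in this assay, with a range from 30000 nM to 250000 nM.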

Compound 4, half-maximal cytotoxic concentration: > 50000 nM
Compound 4: no number, only a limit; the forecaster's own chance of this, stated with the estimate: 85%; the middle value lies beyond the limit too.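

For the compounds shown here, compound 4 ends at a limit of the assay, as compound 1 does, so methyl in place of hydrogen gives no step that can be read: the limit of > 50000 nM in this assay, at which 4 of the 4 values shown sit. In this assay the compounds shown leave open what concentration of any of them would reach the half-maximal cytotoxic level, and whether this methyl changes it.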